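From Tert-Butyl to Cyano on a Shared Core

The compounds below may be only part of what the source reports. "The series", "measured", "known", "first", "only" and "open" are said of these compounds alone.

Four compounds share one core and differ only in the group on one aromatic ring. In a functional assay on MDA-MB-231 cells (Homo sapiens) for cytotoxicity, read by MTT assay, with a stated time of 48 h (on this read-out higher numbers stand for weaker inhibition and lower numbers for stronger inhibition), compound 1 `O=c1ccoc2cc(OCc3cn(Cc4ccc(Cl)cc4Cl)nn3)ccc12` gives > 100000 nM, which is a limit of the assay rather than a number. Compound 2 `O=c1ccoc2cc(OCc3cn(Cc4ccccc4Cl)nn3)ccc12` gives 15100 nM in this assay. Compound 3 `CC(C)(C)c1ccc(Cn2cc(COc3ccc4c(=O)ccoc4c3)nn2)cc1` gives > 100000 nM, again a limit. That limit is the limit of > 100000 nM in this assay, at which 2 of the 3 values shown sit. Going by the values given here, the one measured step, an at least 6.6-fold lower number from compound 1 to compound 2 (0.82 log units; beyond the scatter), shows that changing a substituent on this ring can move the number at least modestly, though it concerns a different group. Compound 4 `N#Cc1ccc(Cn2cc(COc3ccc4c(=O)ccoc4c3)nn2)cc1` carries cyano in place of tert-butyl on an aromatic carbon. Among the compounds with values here, no measured step matches this change, so compound 4 is expected to stay near the limit, with an at least 1.6-fold lower number from compound 3 to compound 4 (0.22 log units; that floor lies within the scatter) as an expected modest gain at best. The estimate for compound 4 is 60000 nM, with a range from 15000 nM to 200000 nM.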

Compound 4, half-maximal inhibitory concentration: > 100000 nM
Compound 4 ended at the assay's limit; the forecaster's own chance of this, stated with the estimate: 50%; middle value at least 1.6-fold (0.22 log units) from the limit.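

With cyano in place of tert-butyl, this ring position still yields only a limit in this assay, so two very different groups here end the same way. Going by these compounds alone, the one readable step is an at least 6.6-fold higher number from compound 2 to compound 4 (0.82 log units; beyond the scatter), and it replaces the whole substituted ring rather than one group. The other steps cannot be read, since both ends of each are limits, a result seen across the set: the limit of > 100000 nM in this assay, at which 3 of the 4 values shown sit.

As far as these compounds go, whether an amine or a carboxylic acid at this position would give a measurable number stays open. So does how compound 1, compound 3 and compound 4 would rank beyond the limit.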